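The source may report more compounds than this note shows. Statements on the series, on what has been measured and on what is new or still open speak of the compounds shown alone.

Compound 1 `N#CCCCn1c(Cn2c(=O)n(Cc3ccc(C#N)cc3)c3ccncc32)nc2ccccc21` gives 36800 nM in an ADME assay on HEp-2 cells (Homo sapiens) for cytotoxicity; a higher number here means that more compound is tolerated, a lower number that less compound is tolerated. Compound 2 `CC(C)S(=O)(=O)n1c(=O)n(Cc2nc3ccccc3n2CCCC#N)c2cnccc21` reaches only a limit of this assay, > 228000 nM. Going by the values given here, the one measured step is an at least 6.1-fold higher number from compound 1 to compound 2 (0.79 log units; beyond the scatter). Compound 3 `CC(C)(C)n1c(=O)n(Cc2nc3ccccc3n2CCCC#N)c2cnccc21` differs from compound 2 by tert-butyl in place of isopropylsulfonyl on an aromatic nitrogen. That measured step exchanged a different group, so it offers no direct guide to this change, and compound 2 itself stands only at a limit. The step from compound 2 to compound 3 is therefore expected to be an at least 1.5-fold lower number from compound 2 to compound 3 (0.18 log units; that floor lies within the scatter), with a real chance that this assay again reports only a limit. Compound 3 is estimated at 150000 nM, between 40000 nM and 300000 nM.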

Compound 3, half-maximal cytotoxic concentration: > 86800 nM
Compound 3 gave a limit, no number (the forecaster's own chance of this, stated with the estimate: 45%); the middle value lies beyond the limit too.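

Putting tert-butyl in place of 4-cyanobenzyl on this aromatic nitrogen gives an at least 2.3-fold higher number from compound 1 to compound 3 (0.37 log units; beyond the scatter) in this assay. The higher number therefore does not need the sulfonyl group, since tert-butyl, with no hydrogen-bond acceptors, moves the same way as isopropylsulfonyl. In this assay compound 3 gives only a limit, > 86800 nM, and with compound 2 also at a limit, the step between them cannot be read.

On these data alone, whether isopropylsulfonyl and tert-butyl differ at all remains open. So does where an amine or a carboxylic acid on this nitrogen would fall in this assay.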